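Trimming one fluoro from a piperazine sulfamide

The source may report more compounds than this note shows. Statements on the series, on what has been measured and on what is new or still open speak of the compounds shown alone.

In an assay on isolated protein for displacement of a labelled ligand from metabotropic glutamate receptor 5 (Homo sapiens), with a stated time of 60 min, tested at 1 uM (a lower number here means less inhibition, a higher number more inhibition at the concentration tested (going by the name of the read-out)), compound 3 `NS(=O)(=O)N1CCN(c2c(S(=O)(=O)c3cc(F)cc(F)c3)cnc3cc(F)ccc23)CC1` gives 6.4%, the lowest of the three measured values. Compound 2 `COCC1CCN(c2c(S(=O)(=O)c3cc(F)cc(F)c3)cnc3cc(F)ccc23)CC1` gives 83% and compound 1 `CC1CCN(c2c(S(=O)(=O)c3ccc(F)cc3)cnc3ccc(Cl)cc23)CC1` gives 89%. Among the compounds with values here, the only measured single change, a number 76.6 percentage points lower from compound 2 to compound 3 (beyond the scatter), concerns the ring on the other side of the shared core and so does not speak to the present question. Compound 4 `NS(=O)(=O)N1CCN(c2c(S(=O)(=O)c3cccc(F)c3)cnc3cc(F)ccc23)CC1` differs from compound 3 by hydrogen in place of fluoro on an aromatic carbon, so that 3,5-difluorophenyl becomes 3-fluorophenyl. Within the data shown here, no measured pair isolates this change; compound 1 carries another fluorophenyl but differs in several places at once. Compound 4 is therefore expected to stay close to where compound 3 lies, with a number 3.6 percentage points higher from compound 3 to compound 4 (within the scatter) remaining within the scatter. The estimate for compound 4 in this assay is 10%, from 0% to 35%.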

Compound 4, a percentage reported as inhibition, at one concentration (the size of the read-out at that concentration, not a potency): 1.9%
Beside the measured number, compound 4's estimate is 8.1 percentage points above it; measured number inside the range.
By their numbers in this assay, from the lowest: compounds 4 and 3 (each within the scatter of the next); then compounds 2 and 1 (each within the scatter of the next).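

In this assay, within the data shown here, this is the first reading of a change on the sulfonyl-bound aryl ring alone: going from 3,5-difluorophenyl to 3-fluorophenyl gives a number 4.5 percentage points lower from compound 3 to compound 4 (within the scatter), so the two compounds cannot be told apart. With the sulfamoylpiperazine in place, inhibition stays low with or without this fluoro. Nothing available here explains this result.

Going by these compounds, it remains open whether the same swap would matter with the 4-(methoxymethyl)piperidin-1-yl group of compound 2, where inhibition is high. Also open, on these data alone, is how a methoxy group or an amine would behave on this carbon.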